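Swapping a Para Fluoro for Methoxy on the Benzyl Ether

The compounds below may be only part of what the source reports. "The series", "measured", "known", "first", "only" and "open" are said of these compounds alone.

Compound 1 `FC(F)(F)c1ccc(CN2CCN(Cc3cc(-c4ccc(OCc5ccccc5Cl)cc4)on3)CC2)cc1`: 1000 nM
Compound 2 `Fc1cccc(COc2ccc(-c3cc(CN4CCN(Cc5ccc(C(F)(F)F)cc5)CC4)no3)cc2)c1`: 1300 nM
Compound 3 `Fc1ccc(COc2ccc(-c3cc(CN4CCN(Cc5ccc(C(F)(F)F)cc5)CC4)no3)cc2)cc1`: 2000 nM

All three were measured in a functional assay on Huh-7 cells (Homo sapiens) for antiproliferative activity, read by sulforhodamine B assay, with a stated time of 72 h; on this read-out higher numbers stand for weaker inhibition and lower numbers for stronger inhibition. Compound 3 gives the highest of the three numbers, yet every step leading to it lies within the scatter: a 2.0-fold higher number from compound 1 to compound 3 (0.30 log units; within the scatter) and a 1.5-fold higher number from compound 2 to compound 3 (0.19 log units; within the scatter), while between the other two the step is a 1.3-fold higher number from compound 1 to compound 2 (0.11 log units; within the scatter). On these numbers the three compounds cannot be told apart; moving a halogen around the benzyl ring of the ether has not produced a step larger than repeated measurement would give.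

Compound 4 `COc1ccc(COc2ccc(-c3cc(CN4CCN(Cc5ccc(C(F)(F)F)cc5)CC4)no3)cc2)cc1` is the next step from compound 3. The change is methoxy in place of fluoro on an aromatic carbon. Within the data shown here, none of the measured steps involves a methoxy group; the three that exist all concern halogens on that same benzyl ring, and all are within the scatter. Nothing in the data points in either direction, so the step of no change at the digits printed from compound 3 to compound 4 (within the scatter) is expected to remain within the scatter. Compound 4 is therefore estimated at 2000 nM in this assay, with a range from 800 nM to 5000 nM. Among the measured compounds shown here, no measured step bears directly on a methoxy group, and the range is set wide to reflect that.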

Compound 4, half-maximal inhibitory concentration: 3200 nM
Compound 4: middle estimate off by 1.6-fold (0.20 log units), on the low side; the range from low to high includes it.
By their numbers in this assay, from the lowest: compounds 1, 2, 3 and 4 (each within the scatter of the next, the first and the last beyond it).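

Methoxy in place of fluoro is the first group on this carbon of the benzyl ring that is not a halogen, and in this assay the change gives a 1.6-fold higher number from compound 3 to compound 4 (0.20 log units; within the scatter) on its own, so it cannot be told apart from repeat measurement. Compared with the other two compounds, however, the same 4-methoxyphenyl ether gives a 2.5-fold higher number from compound 2 to compound 4 (0.39 log units; beyond the scatter) and a 3.2-fold higher number from compound 1 to compound 4 (0.51 log units; beyond the scatter) as well, the first steps on this ring to pass beyond the scatter, which shows that this part of the molecule can shift the number modestly, although each of these steps changes both the group and where it sits on the ring. Nothing measured here accounts for these differences.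

The compounds shown leave open what an amine or a carboxylic acid on this aromatic carbon would do to the number, and whether a longer chain, such as ethoxy in place of methoxy, would take it further in the same direction. They also leave open whether a methoxy group on another carbon of the ring would give a similar number.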